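Swapping the morpholine ring for pyrrolidine on compound 1

The compounds below may be only part of what the source reports. "The series", "measured", "known", "first", "only" and "open" are said of these compounds alone.

Compound 1, `N/C(=N\NC(=S)N1CCOCC1)c1ccccn1`, was tested in a functional assay on A-375 cells (Homo sapiens) for cytotoxicity, read by MTT assay, with a stated time of 72 h, tested at 1 uM (on this read-out higher numbers stand for more inhibition of growth at the one concentration tested and lower numbers for less inhibition of growth), and gives 26.8%. Among the three measured compounds, compound 1 stands at the low end. Compound 2, `Cc1ccnc(/C(N)=N/NC(=S)N2CCOCC2)c1`, gives 43.2% in this assay, and the change a number 16.4 percentage points higher from compound 1 to compound 2 (beyond the scatter) is a methyl in place of hydrogen on an aromatic carbon. Compound 3, `Cc1cccc(/C(N)=N/NC(=S)N2CCOCC2)n1`, gives 30.2%, and the change a number 3.4 percentage points higher from compound 1 to compound 3 (within the scatter) is also a methyl in place of hydrogen on an aromatic carbon, at a different place.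

Compound 4, `N/C(=N\NC(=S)N1CCCC1)c1ccccn1`, is not yet measured. It differs from compound 1 in one place: pyrrolidin-1-yl in place of morpholin-4-yl on a thiocarbonyl carbon. This change sits on the thiocarbonyl carbon, far from the aromatic carbons that were varied in the two measured steps, so neither of those steps bears directly on it. The measured steps show that a small change to the shared core moved the read-out at most by a modest amount, and one of them stayed within the scatter. For the measured compounds named here, with no closer precedent, the expected step from compound 1 to compound 4 is a number 3.2 percentage points higher from compound 1 to compound 4 (within the scatter), that is, no change beyond the scatter is expected. Compound 4 is therefore estimated to give about 30% in this assay, with a likely range from 10% to 55%.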

Compound 4, percent growth inhibition at one concentration: 65.7%
Compound 4: middle estimate off by 35.7 percentage points, on the low side; the measured number lies above the stated range.
By their numbers in this assay, from the lowest: compounds 1 and 3 (each within the scatter of the next); then compound 2; then compound 4.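

In this assay, the thiocarbonyl carbon proves to be a place where the read-out responds strongly: pyrrolidin-1-yl in place of morpholin-4-yl gives a number 38.9 percentage points higher from compound 1 to compound 4 (beyond the scatter). The earlier changes on aromatic carbons gave a number 16.4 percentage points higher from compound 1 to compound 2 (beyond the scatter) and a number 3.4 percentage points higher from compound 1 to compound 3 (within the scatter), so among these compounds the largest step comes from the group on the thiocarbonyl carbon, not from a methyl on the aromatic ring. This single swap changes the ring size and removes the ring oxygen together, so it cannot tell which of the two goes with the higher number, and no data here explain the rise.

Piperidine, a six-membered ring without the oxygen, would separate those two differences, while an open-chain group such as dimethylamino would show whether a ring is needed on the thiocarbonyl carbon at all. On these data alone, it also remains open whether the methyl that raised the number in compound 2 would add to the pyrrolidin-1-yl step if both changes were present in one compound.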